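Swapping Vinyl for Phenyl on the Shared Core

The source may report more compounds than this note shows. Statements on the series, on what has been measured and on what is new or still open speak of the compounds shown alone.

Compound 2 `C=C/C=C1\C=C(C)C2(CC2)C(C)(O)C1=O` gives 18 nM in a functional assay on A-375 cells (Homo sapiens) for antiproliferative activity (on this read-out higher numbers stand for weaker inhibition and lower numbers for stronger inhibition), the only plain number shown. Compound 1 `CC1=C/C(=C\c2cccs2)C(=O)C(C)(O)C12CC2` reaches only a limit there, > 10000 nM, as the limit of > 10000 nM in this assay, at which 1 of the 2 values shown sits, records. Among the measured compounds shown here, the single measured step, an at least 550-fold lower number from compound 1 to compound 2 (2.74 log units; beyond the scatter), is large. Compound 3 `CC1=C/C(=C\c2ccccc2)C(=O)C(C)(O)C12CC2` differs from compound 2 by phenyl in place of vinyl on a double-bonded chain carbon bound to a double-bonded ring carbon. Phenyl, like thiophen-2-yl, is an aromatic ring, and an upward step in this assay roughly reversing an at least 550-fold lower number from compound 1 to compound 2 (2.74 log units; beyond the scatter) is expected, though a limit may again be all that is read. Compound 3 is therefore estimated at 5000 nM, between 500 nM and 20000 nM, an expected step of a 280-fold higher number from compound 2 to compound 3 (2.44 log units; beyond the scatter).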

Compound 3, half-maximal inhibitory concentration: > 10000 nM
Compound 3 was reported as a limit; the forecaster's own chance of this, stated with the estimate: 45%; at least 2.0-fold (0.30 log units) between middle value and limit.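

Phenyl in place of vinyl on this double-bonded chain carbon brings an at least 550-fold higher number from compound 2 to compound 3 (2.74 log units; beyond the scatter). With thiophen-2-yl in compound 1 and now phenyl in compound 3, both aromatic rings shown at this place give far weaker inhibition than vinyl in compound 2. Compound 3 joins compound 1 at a limit of the assay, so the step between them cannot be read: the limit of > 10000 nM in this assay, at which 2 of the 3 values shown sit.

On these data alone, how much activity either ring retains stays unknown. Also open, as far as these compounds go, is whether ethyl, which lacks the double bond of vinyl, or a longer chain such as propenyl would keep the low number of compound 2.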